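This account rests on a few compounds, and the source may have more. Where it says the series, first, only, none or still open, it means among the compounds named here.

In a functional assay on A549 cells (Homo sapiens) for inhibition, read by MTT assay, with a stated time of 48 h (a higher number here means a weaker inhibitor of growth, a lower number a stronger inhibitor of growth), three compounds that share one core differ only in a single substituent on an aromatic carbon. Compound 1 `Cn1cc(C2CC(c3ccccc3)=NN2C(=O)c2cccnc2)c2ccccc21`, which carries hydrogen there, gives > 10000 nM, a limit of the assay and not a number. Compound 2 `Cn1cc(C2CC(c3ccccc3)=NN2C(=O)c2ccc(Cl)nc2)c2ccccc21`, with chloro, gives 8460 nM. Among the compounds with values here, compound 3 `COc1ccc(C(=O)N2N=C(c3ccccc3)CC2c2cn(C)c3ccccc23)cn1`, with methoxy, gives 3040 nM, the lowest of the numbers so far.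

Compound 4 `Cc1ccc(C(=O)N2N=C(c3ccccc3)CC2c2cn(C)c3ccccc23)cn1` has methyl in place of methoxy, turning 6-methoxypyridin-3-yl into 6-methylpyridin-3-yl: methyl in place of methoxy on an aromatic carbon. The change lies next to the ring nitrogen, para to a large group.

Within the data shown here, no methyl compound has been measured, so the evidence is indirect. Methoxy gave an at least 3.2-fold lower number from compound 1 to compound 3 (0.51 log units; beyond the scatter) and a 2.8-fold lower number from compound 2 to compound 3 (0.44 log units; beyond the scatter), whereas chloro gave only an at least 1.1-fold lower number from compound 1 to compound 2 (0.07 log units; that floor lies within the scatter). Losing the methoxy group from compound 3 may therefore give back part of that gain. A modest move to a higher number in this assay is expected, with the estimated step being a 1.8-fold higher number from compound 3 to compound 4 (0.26 log units; within the scatter). Compound 4 is estimated at 5500 nM, with an expected range of 2400 nM to 12000 nM.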

Compound 4, concentration for 50% growth inhibition: 1190 nM
Compound 4: the middle estimate sits 4.6-fold (0.66 log units) above what was measured; measured number outside the range, below it.
By their numbers in this assay, from the lowest: compound 4; then compound 3; then compound 2. At a limit, above all of these: compound 1.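

In this assay, the oxygen of the methoxy group is not needed for a low number at this place next to the ring nitrogen, since removing it gives a 2.6-fold lower number from compound 3 to compound 4 (0.41 log units; beyond the scatter). Methyl also outdoes chloro, with a 7.1-fold lower number from compound 2 to compound 4 (0.85 log units; beyond the scatter), and hydrogen, with an at least 8.4-fold lower number from compound 1 to compound 4 (0.92 log units; beyond the scatter), so compound 4 now stands lowest of the series, and each of its steps lies beyond the scatter. The step from compound 1 is only a floor, as the entry for compound 1 is a limit of the assay and not a number: the limit of > 10000 nM in this assay, at which 1 of the 4 values shown sits.

The compounds shown leave open whether an ethyl group, a longer chain or an amine at this place would lower the number further. They also give no cause for the order seen among these groups.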